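Benzyl isomer swap in the cyclic sulfonylurea series

A few compounds are considered here, and "the series" means these few. Any claim that something is new, unique, unknown or untested is made for them only; others in the source may bear on it.

Compound 1 `COc1ccc(N2C(=O)N(Cc3c(F)cc(F)cc3OC)c3ccccc3S2(=O)=O)cc1OC` gives 63.1 nM in an assay on isolated protein for displacement of a labelled ligand from Orexin/Hypocretin receptor type 1 (Homo sapiens), with a stated time of 90 min (on this read-out higher numbers stand for weaker inhibition and lower numbers for stronger inhibition), the highest number of the three measured compounds; compound 3 `COc1ccc(N2C(=O)N(Cc3c(F)cccc3Cl)c3ccccc3S2(=O)=O)cc1OC` gives 7.94 nM and compound 2 `COc1cc(F)c(CN2C(=O)N(c3cnc(OC)c(OC)c3)S(=O)(=O)c3ccccc32)c(F)c1` gives 2.51 nM. The unmeasured compound 4 `COc1cc(F)c(CN2C(=O)N(c3ccc(OC)c(OC)c3)S(=O)(=O)c3ccccc32)c(F)c1` keeps the core of compound 1 and differs only on the benzyl: 2,6-difluoro-4-methoxyphenyl in place of 2,4-difluoro-6-methoxyphenyl on a saturated chain carbon bound to an amide-type nitrogen in a ring.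

Within the data shown here, the one measured step at the same place, a 7.9-fold lower number from compound 1 to compound 3 (0.90 log units; beyond the scatter), shows that replacing the 2,4-difluoro-6-methoxyphenyl of compound 1 lowers the number well beyond the scatter. Compound 2 carries the same 2,6-difluoro-4-methoxyphenyl group as compound 4 on a different aryl ring. In this assay, among the measured compounds shown here, compound 2 gives 2.51 nM, a number far below that of compound 1; no single step connects those two, so only the values are compared here.

For compound 4 a lower number than compound 1 is therefore expected, a step of a 7.9-fold lower number from compound 1 to compound 4 (0.90 log units; beyond the scatter), on the order of the step to compound 3. The estimate for compound 4 is 8 nM, within 2.5 nM to 25 nM.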

Compound 4, inhibition constant: 2 nM
Estimate against measurement, compound 4: 4.0-fold (0.60 log units) above, outside the stated range (below it).
By their numbers in this assay, from the lowest: compounds 4 and 2 (each within the scatter of the next); then compound 3; then compound 1.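

In this assay, the same atoms rearranged on the benzyl give a 32-fold lower number from compound 1 to compound 4 (1.50 log units; beyond the scatter), so on a saturated chain carbon bound to an amide-type nitrogen in a ring, the arrangement of the methoxy and the two fluorines matters and not just their presence. The 2,6-difluoro-4-methoxyphenyl group also goes beyond the 2-chloro-6-fluorophenyl group, with a 4.0-fold lower number from compound 3 to compound 4 (0.60 log units; beyond the scatter), so compound 3 did not mark the best number reached at this place. With this benzyl kept, 3,4-dimethoxyphenyl in place of 5,6-dimethoxypyridin-3-yl on an amide-type nitrogen in a ring gives a 1.3-fold lower number from compound 2 to compound 4 (0.10 log units; within the scatter), which leaves the two aryl groups not separated here.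

What lies behind the effect of the rearrangement stays open, as nothing at hand bears on it. Also open, from the compounds shown here alone, is how a dimethylamino group or a carboxylic acid in place of the methoxy on the benzyl would read.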